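Thiophen-3-yl in Place of Pentyl: an Expected Growth Value

The compounds below may be only part of what the source reports. "The series", "measured", "known", "first", "only" and "open" are said of these compounds alone.

Compound 1 `CCCCCc1cc2nn(-c3ccccc3)cc2cn1`: 2100 nM
Compound 2 `CCCCCc1cc2nn(-c3ccccc3)cc2c(C)n1`: 6900 nM

In a functional assay on K562 cells (Homo sapiens) for inhibition, read by fluorescence, with a stated time of 72 h (a higher number here means a weaker inhibitor of growth, a lower number a stronger inhibitor of growth), compound 1 gives the lowest of the two numbers, and its nearest neighbour is compound 2, reached by a 3.3-fold higher number from compound 1 to compound 2 (0.52 log units; beyond the scatter). Compound 3 `c1ccc(-n2cc3cnc(-c4ccsc4)cc3n2)cc1` differs from compound 1 by thiophen-3-yl in place of pentyl on an aromatic carbon. Going by the values given here, the only measured step, methyl in place of hydrogen, concerns a different change, so no measured step bears on this one. Without such guidance, the number for compound 3 in this assay is expected to stay close to that of compound 1, with an estimated step of no change at the digits printed from compound 1 to compound 3 (within the scatter) and a wide range. Compound 3 is thus estimated at 2100 nM, between 500 nM and 9000 nM.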

Compound 3, concentration for 50% growth inhibition: 8300 nM
For compound 3 the middle estimate is 4.0-fold (0.60 log units) below the measured one; measured number inside the range.
By their numbers in this assay, from the lowest: compound 1; then compounds 2 and 3 (each within the scatter of the next).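

Compounds 1 and 2 both carry pentyl, so they showed nothing about this place; on the aromatic carbon next to the ring nitrogen, thiophen-3-yl in place of pentyl gives a 4.0-fold higher number from compound 1 to compound 3 (0.60 log units; beyond the scatter) in this assay. The number at this place thus depends on the group it carries, even though pentyl and thiophen-3-yl have the same heavy-atom count. No measurement at hand says why the number rises.

Whether this rise belongs to thiophen-3-yl alone or to other rings remains open: none of the compounds shown carries phenyl, an amine or a shorter chain such as propyl at this place.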